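Changing the side chain of compound 1

A few compounds are considered here, and "the series" means these few. Any claim that something is new, unique, unknown or untested is made for them only; others in the source may bear on it.

Values in a physicochemical assay for solubility, in phosphate buffer, at pH 7.2 (on this read-out higher numbers stand for higher solubility and lower numbers for lower solubility), so far:
compound 1 `COc1cc(C2CN(C(=O)c3cc(OC[C@@H](O)CO)ccn3)C2)ccc1OCc1ccc(C2CC2)cc1` gives 3100 nM
compound 2 `COc1cc(C2CN(C(=O)c3cc(OCCCC(=O)O)ccn3)C2)ccc1OCc1ccc(C2CC2)cc1` gives 1100 nM
compound 3 `CCc1ccc(COc2ccc(C3CN(C(=O)c4cc(COC[C@@H](O)CO)ccn4)C3)cc2OC)cc1` gives 7100 nM

Of these three numbers, compound 1 holds the middle place, the second highest. Compound 4 `COc1cc(C2CN(C(=O)c3cc(COCC(CO)CO)ccn3)C2)ccc1OCc1ccc(C2CC2)cc1` differs from compound 1 in one place (3-hydroxy-2-(hydroxymethyl)propoxy)methyl in place of 2,3-dihydroxypropoxy on an aromatic carbon with (3-hydroxy-2-(hydroxymethyl)propoxy)methyl in place of 2,3-dihydroxypropoxy on an aromatic carbon. Among the measured compounds shown here, the one measured step from compound 1, a 2.8-fold lower number from compound 1 to compound 2 (0.45 log units; beyond the scatter) (modest), is a different exchange, 2-carboxyethyl in place of 1,2-dihydroxyethyl, so it bears only loosely. For the measured compounds named here, compound 3 differs from compound 1 in more than one place and offers no clean step. In this assay no change beyond the scatter is therefore expected, and the expected size is a 1.1-fold higher number from compound 1 to compound 4 (0.05 log units; within the scatter) at most loosely. For compound 4 the estimated value is 3500 nM with an expected range of 1300 nM to 9000 nM in this read-out.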

Compound 4, solubility: 4700 nM
Beside the measured number, compound 4's estimate is 1.3-fold (0.13 log units) below it, within the range that was stated.
By their numbers in this assay, from the lowest: compound 2; then compounds 1, 4 and 3 (each within the scatter of the next, the first and the last beyond it).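

In this assay, putting (3-hydroxy-2-(hydroxymethyl)propoxy)methyl in place of 2,3-dihydroxypropoxy on this aromatic carbon gives a 1.5-fold higher number from compound 1 to compound 4 (0.18 log units; within the scatter) even though the entering group has more heavy atoms and no defined stereocentre. Against 3-carboxypropoxy, the same group gives a 4.3-fold higher number from compound 2 to compound 4 (0.63 log units; beyond the scatter) and this step lies beyond the scatter. No supporting measurement explains either step.
Going by these compounds, how an amine or a longer chain bearing further hydroxyl groups on this aromatic carbon would read in this assay remains open.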